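Methoxy on the benzyl ring: carried over to a cyanophenyl core

The compounds below may be only part of what the source reports. "The series", "measured", "known", "first", "only" and "open" are said of these compounds alone.

Values in a functional assay on CHO-K1 cells for antagonist activity at adenosine receptor A1 (Homo sapiens), read by a beta-galactosidase reporter and cAMP accumulation, with stated times of 15 min and 6 h; a higher number here means a weaker inhibitor, a lower number a stronger inhibitor:
compound 1 `Cc1csc(-c2nc(N)c3cc(Cc4ccccc4)sc3n2)n1` — 1490 nM
compound 2 `COc1ccccc1Cc1cc2c(N)nc(-c3nc(C)cs3)nc2s1` — 186 nM
compound 3 `N#Cc1cccc(-c2nc(N)c3cc(Cc4ccccc4)sc3n2)c1` — 222 nM

From compound 1 to compound 2 the change is methoxy in place of hydrogen on an aromatic carbon; in this assay it gave an 8.0-fold lower number from compound 1 to compound 2 (0.90 log units; beyond the scatter). The two cores differ by 3-cyanophenyl in place of 4-methyl-1,3-thiazol-2-yl on an aromatic carbon, which on its own gave a 6.7-fold lower number from compound 1 to compound 3 (0.83 log units; beyond the scatter); compound 2 and compound 3 lie within the scatter of each other. Compound 4 `COc1ccccc1Cc1cc2c(N)nc(-c3cccc(C#N)c3)nc2s1` carries the same change onto the core of compound 3: methoxy in place of hydrogen on an aromatic carbon, at the same place as before. Among the compounds with values here, only one earlier instance exists, so its size is taken as a guide with some caution. In this assay the step from compound 3 to compound 4 is expected to be a 5.6-fold lower number from compound 3 to compound 4 (0.74 log units; beyond the scatter), resting on compound 2 and its step of an 8.0-fold lower number from compound 1 to compound 2 (0.90 log units; beyond the scatter). Compound 4 is therefore estimated at 40 nM, between 12 nM and 130 nM.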

Compound 4, inhibition constant: 129 nM
Beside the measured number, compound 4's estimate is 3.2-fold (0.51 log units) below it; low and high end bracket the measured number.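

In this assay the methoxy change does not carry over from one core to the other at its earlier size: the same change on two cores in this assay, an 8.0-fold lower number (0.90 log units; beyond the scatter) from compound 1 to compound 2 and a 1.7-fold lower number (0.24 log units; within the scatter) from compound 3 to compound 4, 4.7-fold (0.67 log units) apart, beyond the scatter of two such steps. On the second core the step is a 1.7-fold lower number from compound 3 to compound 4 (0.24 log units; within the scatter), and with the methoxy in place the exchange of 4-methyl-1,3-thiazol-2-yl for 3-cyanophenyl gives only a 1.4-fold lower number from compound 2 to compound 4 (0.16 log units; within the scatter): the same change on two cores in this assay, a 6.7-fold lower number (0.83 log units; beyond the scatter) from compound 1 to compound 3 and a 1.4-fold lower number (0.16 log units; within the scatter) from compound 2 to compound 4, 4.7-fold (0.67 log units) apart, beyond the scatter of two such steps. Two cores set no rule for the size of this step on a third, and these numbers do not show why the two steps differ.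

Still open, as far as these compounds go, is whether another group at the same place, such as ethoxy, fluorine or an amine, would also give steps that differ between the two cores. From the compounds shown here alone, whether the methoxy step on a third core would lie nearer the larger or the smaller step also remains open.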